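Trimming the Amine Side Chain: From Compound 2 to Compound 3

This account rests on a few compounds, and the source may have more. Where it says the series, first, only, none or still open, it means among the compounds named here.

Three compounds share one core and differ only in the group attached to the chain carbon. Compound 1 `CC(C)N(CC(C1CCCCC1)N1CCN(C(=O)[C@@H]2CN(C(C)(C)C)C[C@H]2c2ccc(F)cc2F)CC1)S(C)(=O)=O` carries a sulfonamide there; in a functional assay on CHO cells for agonist activity at Melanocortin receptor 4 (Homo sapiens), read by cAMP accumulation (a lower number here means that less compound is needed, a higher number that more compound is needed for the effect), compound 1 gives 13 nM; 25 nM (2 entries). Its repeated entries the several entries of compound 1 in this assay, 13 nM; 25 nM (2 entries) agree with each other within the usual scatter. Compound 2 `CC(C)CN(CC(C)C)CC(C1CCCCC1)N1CCN(C(=O)[C@@H]2CN(C(C)(C)C)C[C@H]2c2ccc(F)cc2F)CC1` carries a diisobutylamino group at the same place, and in this assay compound 2 gives 6700 nM. Going by the values given here, that is the only number for compound 2 in this assay; one further entry gives no single number. Set side by side, the values show that compound 2 needs far more material than compound 1 for the same effect.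

Compound 3 `CC(C)NCC(C1CCCCC1)N1CCN(C(=O)[C@@H]2CN(C(C)(C)C)C[C@H]2c2ccc(F)cc2F)CC1` has not been measured yet. It differs from compound 2 by isopropylamino in place of diisobutylamino on a saturated chain carbon, two bonds along the chain from an amine nitrogen in a ring and a saturated ring carbon, a much smaller group with a hydrogen-bond donor where compound 2 has none. Among the compounds with values here, no measured pair covers exactly this change. Starting from compound 2 at 6700 nM, the step from compound 2 to compound 3 is expected to be a 17-fold lower number from compound 2 to compound 3 (1.22 log units; beyond the scatter), toward a lower number and beyond the scatter. Compound 3 is therefore estimated at 400 nM in this assay, within a range from 60 nM to 2500 nM.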

Compound 3, half-maximal effective concentration: 240 nM
Estimate against measurement, compound 3: 1.7-fold (0.22 log units) above; low and high end bracket the measured number.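

Going by these compounds alone, until now this place on the chain was known only from two very different groups, and compound 3 supplies the first step that can be read there: in this assay, isopropylamino in place of diisobutylamino gives a 28-fold lower number from compound 2 to compound 3 (1.45 log units; beyond the scatter). The result shows that a sulfonamide is not needed to move far away from the high number of compound 2, because a plain amine carrying a smaller group already does much of that work (the several entries of compound 1 in this assay, 13 nM; 25 nM (2 entries)). The change removes heavy atoms and adds a hydrogen-bond donor in a single move, and nothing measured here tells which of the two matters or why the number falls.

Compound 3 at 240 nM still stands at a higher number than compound 1 at 13 nM; 25 nM (2 entries), and the compounds shown leave open what the methanesulfonyl group on that nitrogen contributes to this gap. Also open, going by these compounds, is how a simple primary amine, a dimethylamino group or a diisopropylamino group would behave at this place, which could separate the size of the group from the presence of the amine hydrogen.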